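The compounds below may be only part of what the source reports. "The series", "measured", "known", "first", "only" and "open" are said of these compounds alone.

Measured compounds in a functional assay on HCT-116 cells (Homo sapiens) for cytotoxicity, read by MTT assay, with a stated time of 72 h; on this read-out lower numbers stand for stronger inhibition and higher numbers for weaker inhibition:
compound 1, `C[C@@H](Nc1c(C(=O)NCc2ccc(F)cc2)nc(Br)c2cccnc12)c1ccccc1`: > 20000 nM
compound 2, `C[C@H](CO)Nc1nc(C(=O)NCc2ccc(F)cc2)c(O)c2ncccc12`: "not determined" (no result reported)

For the measured compounds named here, compound 1 sits at a limit of this assay, with no single number, and it stands alone among the measured entries, so no step between measured compounds is available (the limit of > 20000 nM in this assay, at which 1 of the 2 values shown sits). Compound 3, `O=C(NCc1ccc(F)cc1)c1nc(Br)c2cccnc2c1NCc1ccccc1`, differs from compound 1 in hydrogen in place of methyl on a saturated chain carbon bound to an aromatic carbon and a nitrogen on an aromatic ring. Going by the values given here, with no measured step for comparison, no movement beyond the usual scatter is expected a number no higher from compound 1 to compound 3 (the limit leaves the size open). Compound 3 is therefore estimated at 20000 nM, with a range from 8000 nM to 50000 nM, most likely reported again as a limit.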

Compound 3, half-maximal inhibitory concentration: > 20000 nM
Compound 3: no number, only a limit (the forecaster's own chance of this, stated with the estimate: 70%); the middle value lies on the limit itself.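

Compound 1 and compound 3 both give only a limit in this assay, so no step can be read between them. The compounds shown leave open whether 1-phenylethyl to benzyl shifts the read-out at all, and whether any compound in the series gives a single number in this assay.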